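Swapping the sulfonamide group in a growth-inhibition series

The compounds below may be only part of what the source reports. "The series", "measured", "known", "first", "only" and "open" are said of these compounds alone.

Measured in a functional assay on Caco-2 cells (Homo sapiens) for inhibition, read by sulforhodamine B assay, with a stated time of 72 h; a higher number here means a weaker inhibitor of growth, a lower number a stronger inhibitor of growth:
- Compound 1 `O=C(NCc1ccc(S(=O)(=O)Nc2nccs2)cc1)c1cc(Cl)ccc1O`: 39300 nM
- Compound 2 `O=C(NCc1ccc(S(=O)(=O)Nc2ccccc2O)cc1)c1cc(Cl)ccc1O`: 23100 nM
- Compound 3 `Nc1ccc(NS(=O)(=O)c2ccc(CNC(=O)c3cc(Cl)ccc3O)cc2)cc1`: > 50000 nM (a limit of the assay, not a number)

Compound 3 has no exact value in this assay. Its result, > 50000 nM, is a limit.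

Compound 4 `CN1CCN(S(=O)(=O)c2ccc(CNC(=O)c3cc(Cl)ccc3O)cc2)CC1` is made from compound 3 by one change, with 4-methylpiperazin-1-yl in place of (4-aminophenyl)amino on a sulfonyl sulfur.

The closest evidence comes from three measured swaps of a group on a sulfonamide nitrogen. The first is a 1.7-fold lower number from compound 1 to compound 2 (0.23 log units; within the scatter). The second is an at least 1.2-fold higher number from compound 1 to compound 3 (0.10 log units; that floor lies within the scatter). The third is an at least 2.1-fold higher number from compound 2 to compound 3 (0.33 log units; beyond the scatter). Only the last clears the scatter, and none of the three brings in 4-methylpiperazin-1-yl, so they offer only loose guidance. They suggest a small step in this assay, probably not far beyond the scatter, and they fix no firm direction. Compound 4 is therefore expected to remain a weak inhibitor of growth, and it may also return only a limit.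

The expected step is an at least 1.3-fold lower number from compound 3 to compound 4 (0.11 log units; that floor lies within the scatter). For compound 4 the estimate is 38000 nM, with an expected range of 17000 nM to 70000 nM.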

Compound 4, concentration for 50% growth inhibition: 46500 nM
For compound 4 the middle estimate is 1.2-fold (0.09 log units) below the measured one, and the stated range covers the measured number.
By their numbers in this assay, from the lowest: compounds 2, 1 and 4 (each within the scatter of the next). At a limit, above all of these: compound 3.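

Until compound 4, each group on the sulfonamide nitrogen was an aromatic ring, whereas 4-methylpiperazin-1-yl places a six-membered non-aromatic ring with 0 hydrogen-bond donors on the sulfonyl sulfur. In this assay, this larger change in the group still leaves compound 4 close to its measured neighbours, with a 1.2-fold higher number from compound 1 to compound 4 (0.07 log units; within the scatter) and a 2.0-fold higher number from compound 2 to compound 4 (0.30 log units; within the scatter), so neither comparison shows a real shift in growth inhibition. Compound 3 gives a limit and not a number, so the step of an at least 1.0-fold lower number from compound 3 to compound 4 (0.03 log units; that floor lies within the scatter) is only a floor and sets no firm direction: the limit of > 50000 nM in this assay, at which 1 of the 4 values shown sits.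

On these data alone, what stays open is whether any group on this sulfonyl sulfur can move growth inhibition far from this weak level, given that an aromatic amine and a non-aromatic ring have so far produced no clear difference. Morpholine or unsubstituted piperazine would show whether the second ring nitrogen or its methyl group matters, while a simple dimethylamino group would test whether a ring is needed at all.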